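The compounds below may be only part of what the source reports. "The series", "measured", "known", "first", "only" and "open" are said of these compounds alone.

Of the compounds shown here, three that share one core have been tested in a functional assay on PC-3 cells (Homo sapiens) for cytotoxicity, read by MTT assay, with a stated time of 96 h; on this read-out higher numbers stand for weaker inhibition and lower numbers for stronger inhibition. Compound 1 `Cc1ccc(NCc2cnc3cc([N+](=O)[O-])ccc3n2)cc1` gives 57000 nM. Compound 2 `O=C(O)c1ccc(NCc2cnc3cc([N+](=O)[O-])ccc3n2)cc1` gives 45000 nM. Compound 3 `CNC(=O)c1ccc(NCc2cnc3cc([N+](=O)[O-])ccc3n2)cc1` gives 49000 nM. Compound 3 sits among the other two at steps that stay inside the usual spread of repeated measurements: a 1.2-fold lower number from compound 1 to compound 3 (0.07 log units; within the scatter) and a 1.1-fold higher number from compound 2 to compound 3 (0.04 log units; within the scatter), while a 1.3-fold lower number from compound 1 to compound 2 (0.10 log units; within the scatter) is of the same kind.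

Compound 4 `CCNC(=O)c1ccc(NCc2cnc3cc([N+](=O)[O-])ccc3n2)cc1` has not yet been tested. It differs from compound 3 by methyl in place of hydrogen on a saturated chain carbon bound to an amide-type nitrogen. Going by the values given here, no measured step touches this same place; the closest is the change at the carbonyl carbon, a 1.1-fold higher number from compound 2 to compound 3 (0.04 log units; within the scatter), which stayed inside the scatter, as did the two exchanges on the aromatic carbon. All three measured steps are small, so the added methyl is expected to leave this assay without a change beyond the scatter, that is no change at the digits printed from compound 3 to compound 4 (within the scatter). Compound 4 is therefore estimated at 49000 nM, within a range of 25000 nM to 100000 nM.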

Compound 4, half-maximal inhibitory concentration: 66000 nM
Compound 4: middle estimate off by 1.3-fold (0.13 log units), on the low side, within the range that was stated.
By their numbers in this assay, from the lowest: compounds 2, 3, 1 and 4 (each within the scatter of the next).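

In this assay, methylcarbamoyl to ethylcarbamoyl is the only change shown on the chain carried by the amide-type nitrogen, and it gives a 1.3-fold higher number from compound 3 to compound 4 (0.13 log units; within the scatter), so this place has so far shown no effect that can be told from the scatter. Ethylamino in place of hydroxy on the carbonyl carbon gives a 1.5-fold higher number from compound 2 to compound 4 (0.17 log units; within the scatter), and ethylcarbamoyl in place of methyl on the aromatic carbon gives a 1.2-fold higher number from compound 1 to compound 4 (0.06 log units; within the scatter), so the ethyl amide does not stand apart from either neighbour. No measurement at hand offers a reason for these small steps.

On these data alone, whether a longer chain, a ring or a chain ending in an amine on that nitrogen would move the number beyond the scatter remains open. So does the outcome of replacing the amide hydrogen with a second methyl.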